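Cytotoxicity notes on the amide series: compound 3 to compound 4

This account rests on a few compounds, and the source may have more. Where it says the series, first, only, none or still open, it means among the compounds named here.

Compound 1 `CC(=O)Nc1cccc(-c2ccc(C(=O)N(Cc3cccc(OCCCCCC(=O)O)c3)C(C)C)cc2)c1`: a limit only, > 26000 nM
Compound 2 `CC(C)N(Cc1cccc(OCCCCCC(=O)O)c1)C(=O)c1ccc(-c2ccco2)cc1`: a limit only, > 26000 nM
Compound 3 `CCOC(=O)CCCCCOc1cccc(CN(C(=O)c2ccc(-c3ccco3)cc2)C(C)C)c1`: a limit only, > 26000 nM

Among the compounds with values here, in an ADME assay on HEK293 cells (Homo sapiens) for cytotoxicity, read by CellTiter-Glo and resazurin assay, with a stated time of 72 h (a higher number here means that more compound is needed for the effect, a lower number that less compound is needed), no measured compound gives a number; all three sit at the same limit (the limit of > 26000 nM in this assay, at which 3 of the 3 values shown sit), and compound 3 stands there too. The steps a step that the two limits leave unreadable from compound 1 to compound 2 and a step that the two limits leave unreadable from compound 2 to compound 3 therefore have no readable size. The next compound is compound 4 `CCOC(=O)CCCCCOc1cccc(CN(C(=O)c2ccc(-c3cccc(Cl)c3)cc2)C(C)C)c1`, reached by 3-chlorophenyl in place of furan-2-yl on an aromatic carbon. Within the data shown here, the one earlier exchange of an aromatic group, from compound 1 to compound 2, also sat between two limits, so nothing measured suggests a step beyond the scatter in this assay. Compound 4 is expected at 30000 nM, between 10000 nM and 100000 nM, which would be a step that the limit leaves unreadable from compound 3 to compound 4, most likely reported again as a limit.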

Compound 4, half-maximal effective concentration: > 18400 nM
Compound 4 was reported as a limit; the forecaster's own chance of this, stated with the estimate: 80%; the middle value does not contradict the limit.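

Within the data shown here, compound 3 and compound 4 are both reported only as limits, so no step between them can be read. The compounds shown leave open whether any of them has a measurable half-maximal effective concentration in this assay.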